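Trimethoxyphenyl for phenyl on the carbonyl of compound 1

The compounds below may be only part of what the source reports. "The series", "measured", "known", "first", "only" and "open" are said of these compounds alone.

Compound 1 `N#CC1=C(NC(=O)c2ccccc2)N(c2ccc(S(N)(=O)=O)cc2)C2=C(C(=O)CCC2)C1c1ccc(Cl)cc1Cl` is the parent of this pair of notes. Among the measured compounds shown here, in a functional assay on Ehrlich cells (Mus musculus) for cytotoxicity, read by trypan blue exclusion, with a stated time of 2 h, tested at 100 ug/mL (on this read-out higher numbers stand for a stronger effect at the one concentration tested and lower numbers for a weaker effect), compound 1 gives 75%, the higher of the two numbers measured so far. Compound 2 `Cc1ccc(C(=O)NC2=C(C#N)C(c3ccc(Cl)cc3Cl)C3=C(CCCC3=O)N2c2ccc(S(N)(=O)=O)cc2)cc1` carries a methyl in place of hydrogen on an aromatic carbon of the phenyl on the carbonyl carbon; in this assay compound 2 gives 40%, and the step of a number 35 percentage points lower from compound 1 to compound 2 (beyond the scatter) lies beyond the scatter.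

Compound 3 `COc1cc(C(=O)NC2=C(C#N)C(c3ccc(Cl)cc3Cl)C3=C(CCCC3=O)N2c2ccc(S(N)(=O)=O)cc2)cc(OC)c1OC` differs from compound 1 at the same carbonyl carbon, whose other neighbour is the amide-type nitrogen: 3,4,5-trimethoxyphenyl in place of phenyl on a carbonyl carbon. For the measured compounds named here, the only measured step that bears on this change is the one from compound 1 to compound 2, where a single methyl on that ring was enough for a large fall. A heavier change on the same ring is therefore expected to move the number downward as well, though the direction cannot be certain from one step; the expected step is a number 30 percentage points lower from compound 1 to compound 3 (beyond the scatter). Compound 3 is estimated at 45%, within 20% to 70%.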

Compound 3, a percentage reported as activity, at one concentration (the size of the read-out at that concentration, not a potency): 95%
Compound 3: the middle estimate sits 50 percentage points below what was measured; the whole stated range lies below it.
By their numbers in this assay, from the lowest: compound 2; then compound 1; then compound 3.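

In this assay the ring on the carbonyl carbon is not a place where substitution can only lower the number: 3,4,5-trimethoxyphenyl in place of phenyl gives a number 20 percentage points higher from compound 1 to compound 3 (beyond the scatter), the opposite direction to the methyl of compound 2. Between the two substituted rings the gap is wider, with a number 55 percentage points higher from compound 2 to compound 3 (beyond the scatter), so at this place the direction of the change depends on which group the phenyl carries and not merely on its carrying one. No measurement at hand says why 4-methylphenyl and 3,4,5-trimethoxyphenyl part in this way.

The compounds shown leave open whether a methoxy group alone on the phenyl would already raise the number, or whether the rise needs the full 3,4,5-trimethoxyphenyl group, and how an amine or a carboxylic acid on that ring would read. Each number also comes from one concentration, so the order of compound 2, compound 1 and compound 3 gives the size of the effect at that concentration and leaves their potencies open.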